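Series notes: aryl amide variant of compound 3

A few compounds are considered here, and "the series" means these few. Any claim that something is new, unique, unknown or untested is made for them only; others in the source may bear on it.

Compound 1 `Cn1cc(-c2cnc3ccnc(N)c3c2)cn1` gives 33400 nM in a functional assay on A549 cells (Homo sapiens) for antiproliferative activity, read by MTT assay, with a stated time of 48 h; on this read-out lower numbers stand for stronger inhibition and higher numbers for weaker inhibition. Compound 2 `CCNc1ccc2ncc(-c3cnn(C)c3)cc2n1` returns only the assay limit > 50000 nM in this assay. Compound 3 `CC(=O)Nc1nccc2ncc(-c3cnn(C)c3)cc12` also stands at the limit > 50000 nM in this assay, which is the limit of > 50000 nM in this assay, at which 2 of the 3 values shown sit. Among the compounds with values here, the one measured step, an at least 1.4-fold higher number from compound 1 to compound 3 (0.17 log units; that floor lies within the scatter), concerns a different exchange and offers no direct precedent for the present one. Compound 4 `Cn1cc(-c2cnc3ccnc(NC(=O)c4ccc(F)cc4)c3c2)cn1` differs from compound 3 by 4-fluorophenyl in place of methyl on a carbonyl carbon. Within the data shown here, no measured pair shows this change, so the expected step of an at least 1.6-fold lower number from compound 3 to compound 4 (0.22 log units; that floor lies within the scatter) is set at no clear movement beyond the scatter, with the weak end of the series as the starting point. Compound 4 is therefore estimated at 30000 nM, within a range from 5000 nM to 100000 nM, and a limit reading remains quite possible.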

Compound 4, half-maximal inhibitory concentration: > 50000 nM
Compound 4 was reported as a limit; the forecaster's own chance of this, stated with the estimate: 45%; at least 1.6-fold (0.22 log units) between middle value and limit.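

Compound 3 and compound 4 both sit at the assay limit, so no step can be read between them: the limit of > 50000 nM in this assay, at which 3 of the 4 values shown sit.

As far as these compounds go, whether 4-fluorophenyl in place of methyl on a carbonyl carbon changes the read-out at all remains open.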